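Swapping the phenylcarbamoyl of compound 2 for a spiro lactam

The source may hold more compounds than are shown below. What is called first, only, known or untested is meant among the compounds shown, and "the series" means these compounds.

Three compounds in this series share a fluorinated dihydrobenzofuran-methylamine arm on a bicyclic core and were characterised in a physicochemical assay for lipophilicity, using the shake flask method, in phosphate buffer, measured as octanol-water partition, with a stated time of 30 min, at pH 7.4; on this read-out lower numbers stand for lower lipophilicity and higher numbers for higher lipophilicity. Compound 1 `Cn1cc(-c2cnc(NCc3c(F)ccc4c3CCO4)c3cn[nH]c(=O)c23)cn1` gives 2.7, compound 2 `O=C(Nc1ccccc1)c1cnc(NCc2c(F)ccc3c2CCO3)n2cnnc12` gives 4.1, and compound 3 `Cc1ncccc1-c1cnc(NCc2c(F)ccc3c2CCO3)c2n[nH]c(=O)n12` gives 2.5. Compound 2 stands highest of the three; its nearest neighbour is compound 1, which lies lower by a margin beyond the scatter, and compound 3 lies lower still, also beyond the scatter.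

Compound 4 `O=C1CC2(CC2)CN1c1cnc(NCc2c(F)ccc3c2CCO3)n2cnnc12` has not yet been measured in this assay. It keeps the core and the amine arm of compound 2 and differs from it in one place (a group of 8 heavy atoms (6 carbon, 1 nitrogen, 1 oxygen; one three-membered non-aromatic ring of carbon only, one five-membered non-aromatic ring with 1 hetero atom) in place of a group of 9 heavy atoms (7 carbon, 1 nitrogen, 1 oxygen; one six-membered aromatic ring of carbon only), on an aromatic carbon). Among the compounds with values here, no step between two measured compounds tracks this exact change, so its size cannot be read from the data directly. Within the data shown here, still, compound 2, the only compound bearing the phenylcarbamoyl, also holds the highest number, while compounds 1 and 3, which carry other groups, sit well below it. On that basis the step from compound 2 to compound 4 is expected to be a decrease of roughly a number 1.00 log units lower from compound 2 to compound 4 (beyond the scatter), clearly beyond the scatter. Compound 4 is therefore estimated at 3.1, with a likely range from 2.5 to 3.7.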

Compound 4, distribution coefficient: 1.9
For compound 4 the middle estimate is 1.20 log units above the measured one; measured number outside the range, below it.
By their numbers in this assay, from the lowest: compound 4; then compounds 3 and 1 (each within the scatter of the next); then compound 2.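

Within the data shown here, on an aromatic carbon, exchanging the phenylcarbamoyl for the spiro lactam gives, in this assay, a number 2.20 log units lower from compound 2 to compound 4 (beyond the scatter), the first step in this set that can be read between two compounds differing in one place. It shows that this position is far from indifferent to what it carries, since a single exchange here moves the read-out by a large margin. The exchange alters several things at once, taking out one six-membered aromatic ring of carbon only and 1 hydrogen-bond donor and bringing in a three-membered non-aromatic ring of carbon only and a five-membered non-aromatic ring with 1 hetero atom, and no measurement on hand explains the step or ties it to any one of these features.

The compounds shown leave open which of these features carries the step, a question that a cyclohexylcarbamoyl or a plain pyrrolidinone at the same carbon would bear on. They also leave open whether an exchange of this kind would move the read-out similarly on the core of compound 1 or of compound 3.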